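This account rests on a few compounds, and the source may have more. Where it says the series, first, only, none or still open, it means among the compounds named here.

Measured so far:
Compound 1, `CN(c1cccc(NC(=O)CN2N=C(C3CCCCC3)c3ccccc3N(CC(=O)C(C)(C)C)C2=O)c1)c1nn[nH]n1`, 4.68 nM
Compound 2, `CC(C)(C)C(=O)CN1C(=O)N(CC(=O)Nc2cccc(-c3nc(=O)o[nH]3)c2)N=C(C2CCCCC2)c2ccccc21`, 4.47 nM
Compound 3, `O=C(O)CSc1cccc(NC(=O)CN2N=C(C3CCCCC3)c3ccccc3N(CC(=O)C3CCCC3)C2=O)c1`, 4.79 nM

All three were tested in a functional assay on gastric mucosa for displacement of a labelled ligand from Gastrin/cholecystokinin type B receptor (Canis lupus familiaris), read by CCK-8 assay; on this read-out lower numbers stand for stronger inhibition and higher numbers for weaker inhibition. Compound 2 gives the lowest number of the three, but its gap to compound 1 and to compound 3 lies within the scatter, so the three compounds cannot be told apart on these numbers.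

Compound 4, `CC(C)(C)C(=O)CN1C(=O)N(CC(=O)Nc2cccc(CC(=O)O)c2)N=C(C2CCCCC2)c2ccccc21`, has not yet been measured. It is compound 2 with one change: a group of 4 heavy atoms (2 carbon, 2 oxygen; no ring) in place of a group of 6 heavy atoms (2 carbon, 2 nitrogen, 2 oxygen; one five-membered aromatic ring with 3 hetero atoms), on an aromatic carbon.

Among the compounds with values here, the one measured step that speaks to this position is a 1.0-fold lower number from compound 1 to compound 2 (0.02 log units; within the scatter), where one small heterocycle replaced another at the same place without moving the number beyond the scatter. Compound 3, which carries an acid-bearing group on the same ring but also a different ketone side chain, gives 4.79 nM, again close to the others. Within the data shown here, no measured step puts an acid group directly in place of the heterocycle, so the change to compound 4 is not fully covered.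

With the evidence at hand, the step from compound 2 to compound 4 is expected to be a 1.2-fold higher number from compound 2 to compound 4 (0.09 log units; within the scatter), that is, no change beyond the scatter. Compound 4 is therefore estimated at 5.5 nM, with a likely range from 2 nM to 16 nM.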

Compound 4, inhibition constant: 5.25 nM
For compound 4 the middle estimate is 1.0-fold (0.02 log units) above the measured one; the range from low to high includes it.
By their numbers in this assay, from the lowest: compounds 2, 1, 3 and 4 (each within the scatter of the next).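

Carboxymethyl, a group with no ring, can stand in place of the five-membered aromatic ring of compound 2 on this aromatic carbon: this assay shows a 1.2-fold higher number from compound 2 to compound 4 (0.07 log units; within the scatter). Measured against the (2H-tetrazol-5-yl)(methyl)amino group, carboxymethyl gives a 1.1-fold higher number from compound 1 to compound 4 (0.05 log units; within the scatter), so with the rest of the molecule unchanged, these three groups cannot be told apart at this position, and a ring is not needed there to keep the number in this range. Nothing available explains why such different groups read alike.

As far as these compounds go, it remains open whether an amine, or a longer chain ending in a carboxylic acid, on the same aromatic carbon would also stay within the scatter. A plain hydrogen at this position would show whether any of these groups matters to the number at all.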